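The source may report more compounds than this note shows. Statements on the series, on what has been measured and on what is new or still open speak of the compounds shown alone.

Going by the values given here, in a physicochemical assay for lipophilicity, at pH 7.4 (on this read-out higher numbers stand for higher lipophilicity and lower numbers for lower lipophilicity), compound 1 (`N#Cc1ccc(O[C@H]2CN(S(=O)(=O)c3ccc(C(F)(F)F)cc3)C[C@@]2(O)CO)cc1F`) gives 4.5 as the higher of the two numbers so far. Compound 2 (`N#Cc1ccc(O[C@H]2CN(S(=O)(=O)c3ccc(Cl)cc3Cl)C[C@@]2(O)CN)cc1F`) gives 4 and sits lower by more than the usual scatter. These two compounds differ in more than one place, so their gap isolates no single change.

Compound 3 (`N#Cc1ccc(O[C@H]2CN(S(=O)(=O)c3ccccc3C#N)C[C@@]2(O)CO)cc1F`) has not been measured. Relative to compound 1, it carries 2-cyanophenyl in place of 4-(trifluoromethyl)phenyl on a sulfonyl sulfur, counted as 2-cyanophenyl in place of 4-(trifluoromethyl)phenyl on a sulfonyl sulfur in full. Among the compounds with values here, no measured step covers this change, so the expectation rests on the structural change alone and remains uncertain. A downward step beyond the scatter is expected in this assay and is estimated as a number 0.80 log units lower from compound 1 to compound 3 (beyond the scatter) for this pair. For compound 3 the estimated value is 3.7 with an expected range from 3.2 to 4.2 at this stage.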

Compound 3, distribution coefficient: 3.4
Compound 3: the middle estimate sits 0.30 log units above what was measured, within the range that was stated.
By their numbers in this assay, from the lowest: compound 3; then compound 2; then compound 1.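

In this assay, going by these compounds alone, the change of 2-cyanophenyl in place of 4-(trifluoromethyl)phenyl on a sulfonyl sulfur gives a number 1.10 log units lower from compound 1 to compound 3 (beyond the scatter) as the first step that isolates one place. Compounds 1 and 2 differ in more than one place, so only now is the group on a sulfonyl sulfur shown to move this read-out by a large step with the rest of compound 1 held fixed. No measured information bears on the origin of this step.

One step cannot separate the departure of trifluoromethyl from the arrival of nitrile, since both occur in the same exchange of groups. A plain phenyl group on a sulfonyl sulfur, with the rest of compound 1 unchanged, could divide the step into those two parts.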